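Chloro for methyl on the sulfonyl aryl group

The source may hold more compounds than are shown below. What is called first, only, known or untested is meant among the compounds shown, and "the series" means these compounds.

Three sulfonamides share one core and differ only in the aryl group on the sulfonyl sulfur. Compound 1 `COc1ccccc1C(=O)NCc1ccc(CNS(=O)(=O)c2cccc3ccccc23)cc1` carries naphthalen-1-yl, and in an assay on MDA-MB-231 cells for displacement of a labelled ligand from C-X-C chemokine receptor type 4 (Homo sapiens), read by fluorescence and microscopy, with stated times of 10 min and 30 min (a higher number here means that more compound is needed for the effect, a lower number that less compound is needed), compound 1 reaches only the limit > 1000 nM, not a number. Compound 2 `COc1ccccc1C(=O)NCc1ccc(CNS(=O)(=O)c2ccc(F)cc2)cc1` carries 4-fluorophenyl and gives 100 nM in this assay. Compound 3 `COc1ccccc1C(=O)NCc1ccc(CNS(=O)(=O)c2ccccc2C)cc1` carries 2-methylphenyl and gives 1000 nM in this assay. The step of an at least 10-fold lower number from compound 1 to compound 2 (1.00 log units; beyond the scatter) is at least modest; the step of a 10-fold higher number from compound 2 to compound 3 (1.00 log units; beyond the scatter) is modest; the step of a number no higher from compound 1 to compound 3 (the limit leaves the size open) is of unreadable size because of the limit of > 1000 nM in this assay, at which 1 of the 3 values shown sits. Compound 3 therefore holds the highest of the two numbers shown, with compound 2 as its nearest neighbour.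

Compound 4 `COc1ccccc1C(=O)NCc1ccc(CNS(=O)(=O)c2ccccc2Cl)cc1` is not yet measured. Relative to compound 3 the change is chloro in place of methyl on an aromatic carbon. No measured step exchanges chloro for methyl; the steps shown only compare whole aryl groups, and they range from modest to open in size. Nothing in them forces a direction here, so a step within or just beyond the scatter is expected: a 1.4-fold lower number from compound 3 to compound 4 (0.15 log units; within the scatter). Compound 4 is estimated at 700 nM in this assay, in the range 200 nM to 2500 nM.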

Compound 4, effective concentration (reported as EC, without a stated level of effect): 100 nM
For compound 4 the middle estimate is 7.0-fold (0.85 log units) above the measured one, and the stated range ends above it.
By their numbers in this assay, from the lowest: compounds 2 and 4 (each within the scatter of the next); then compound 3.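

At this place, on an aromatic carbon ortho to a large group, exchanging one heavy atom is enough to move the result in this assay: a 10-fold lower number from compound 3 to compound 4 (1.00 log units; beyond the scatter). The earlier gap between 2-methylphenyl and 4-fluorophenyl therefore does not hold for every group at this place, as 2-chlorophenyl gives no change at the digits printed from compound 2 to compound 4 (within the scatter), so in this small set the outcome depends on which group sits there and not simply on whether the place is occupied. Compound 1 gives a limit and not a number, so the comparison with naphthalen-1-yl, an at least 10-fold lower number from compound 1 to compound 4 (1.00 log units; beyond the scatter), fixes a direction but leaves the full size open: the limit of > 1000 nM in this assay, at which 1 of the 4 values shown sits.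

The compounds shown give only chloro and methyl at this place, so it remains open whether a bromo, a methoxy, a nitrile or an amine there would read like compound 4 or like compound 3. What separates chloro from methyl also remains unresolved, as does whether the same exchange would give a comparable step on another aryl group or with a different group in place of the shared core's amide side.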